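The source may hold more compounds than are shown below. What is called first, only, known or untested is meant among the compounds shown, and "the series" means these compounds.

The shared core of compound 2, `Cc1c(OCCCCOCOc2ccc(C(=O)O)cc2)ccc(C(=O)CC2CCCC2)c1O`, carries a four-carbon ether chain that ends in a (4-carboxyphenoxy)methyl group, and in an assay on HEK293 cells for positive allosteric modulation of metabotropic glutamate receptor 2 (Rattus norvegicus), read by thallium flux, with a stated time of 2.5 min (on this read-out higher numbers stand for an effect only at larger amounts of compound and lower numbers for an effect already at smaller amounts), compound 2 gives 228 nM. Of the two numbers that this assay reports, this is the lower one. Compound 1, `Cc1c(OCCCCOc2ccccc2C(=O)O)ccc(C(=O)CC2CCCC2)c1C`, in which the acid sits on a phenyl ring joined directly to the chain oxygen and the core bears a second methyl in place of the hydroxyl, gives 2580 nM in this assay. Compound 3, `Cc1c(OCCCCOc2ccc(C(=O)O)c(Cl)c2)ccc(C(=O)CC(C)C)c1C`, is reported in this assay only as > 10000 nM, which is a limit rather than a number; there (the limit of > 10000 nM in this assay, at which 1 of the 3 values shown sits).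

No two of these compounds differ in a single place, so no measured step is available. Compound 4, `Cc1cc(OCCCCOc2ccc(C(=O)CC3CCCC3)c(O)c2C)ccc1C(=O)O`, differs from compound 2 in one place: 4-carboxy-3-methylphenyl in place of (4-carboxyphenoxy)methyl on an oxygen on a saturated carbon. The hydroxyl of compound 2 is kept.

Without a measured step to lean on, the expectation for compound 4 rests on the span of values that this assay shows. The step from compound 2 to compound 4 is expected to be a 2.2-fold higher number from compound 2 to compound 4 (0.34 log units; beyond the scatter), a modest move towards higher numbers that may not exceed the scatter. Compound 4 is therefore estimated to give 500 nM in this assay, within a range from 150 nM to 2000 nM.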

Compound 4, half-maximal effective concentration: 564 nM
The estimate for compound 4 lay 1.1-fold (0.05 log units) below the measured number; measured number inside the range.
By their numbers in this assay, from the lowest: compound 2; then compound 4; then compound 1. At a limit, above all of these: compound 3.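

In this assay the series now has its first change in one place: exchanging (4-carboxyphenoxy)methyl for 4-carboxy-3-methylphenyl on the oxygen on a saturated carbon gives a 2.5-fold higher number from compound 2 to compound 4 (0.39 log units; beyond the scatter) while the hydroxyl of the core stays. The end of the chain therefore accepts a substantial rewrite of the acid-bearing group at a modest cost on this read-out, even though the entering group has one hydrogen-bond acceptor fewer than the group that leaves. Compound 4 also keeps a measured number rather than a limit, so this position gives a graded response to this change and not a loss of effect.

The exchange alters both the link to the ring and the ring's substitution, so the step cannot say how much of it belongs to the added methyl and how much to the shorter link, and a plain 4-carboxyphenyl group on the same oxygen would be needed to separate the two. Going by these compounds, it also stays open how a tetrazole in place of the carboxylic acid would fare at this position, and nothing measured here gives a reason for the size of the step.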